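Phenyl to 2-chlorophenyl on the shared core

A few compounds are considered here, and "the series" means these few. Any claim that something is new, unique, unknown or untested is made for them only; others in the source may bear on it.

For the measured compounds named here, the series so far holds two measured compounds. Compound 1 `CC(C(=O)N1CCN(c2ccccc2)CC1)N1C(=O)CCC1=O` and compound 2 `CC(C(=O)N1CCOCC1)N1C(=O)CCC1=O` share one core and differ in one ring. In a functional assay on the whole organism (strain Swiss) with Mus musculus as the target, in the maximal electroshock model, with a stated time of 2 h, at a dose of 300 mg/kg by the intraperitoneal route (on this read-out lower numbers stand for a weaker effect and higher numbers for a stronger effect at the one dose given), compound 1 gives 0% and compound 2 gives 0%; compound 1 thus stands level with compound 2 at the digits shown, the gap between them lying within the scatter. Going by the values given here, no step between measured compounds that differ in one place is recorded, so no measured step supplies a size for the next change.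

Compound 3 `CC(C(=O)N1CCN(c2ccccc2Cl)CC1)N1C(=O)CCC1=O` is the next compound in line. It differs from compound 1 by chloro in place of hydrogen on an aromatic carbon. Both measured compounds sit at the same reading, and nothing recorded shows a chloro group shifting this read-out either way. The expected step of no change at the digits printed from compound 1 to compound 3 (within the scatter) is therefore none beyond the scatter, in either direction. Compound 3 is estimated at 0% in this assay, within 0% to 25%.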

Compound 3, a percentage reported as activity, at one dose (the size of the read-out at that dose, not a potency): 0%
For compound 3 middle estimate and measured number coincide at the digits printed, and the stated range covers the measured number.
By their numbers in this assay, from the lowest: compounds 1, 2 and 3 (each within the scatter of the next).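

The series now holds its first measured step between compounds that differ in one place: in this assay, chloro in place of hydrogen on an aromatic carbon, ortho to a large group, gives no change at the digits printed from compound 1 to compound 3 (within the scatter). The phenyl to 2-chlorophenyl change therefore does not bring out a reading in this assay at this one dose, and compound 3 stays at 0%, the same printed reading as compound 1. No supporting finding accounts for this result.

With all three readings at the bottom of the scale, a change toward a weaker effect could not show here, so this position is not shown to be insensitive in general. As far as these compounds go, whether an amine or a carboxylic acid in place of the chloro would give any reading in this assay remains open.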